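The source may report more compounds than this note shows. Statements on the series, on what has been measured and on what is new or still open speak of the compounds shown alone.

Among the measured compounds shown here, compound 1, `Cc1ccccc1-c1noc(CN2C(=O)c3ccccc3C2=O)n1`, and compound 2, `Cc1cccc(-c2noc(CN3C(=O)c4ccccc4C3=O)n2)c1`, are the two measured members of this set. In a functional assay on the whole organism for inhibition, with Mus musculus as the target, in the writhing test, at a dose of 3.12 mg/kg (on this read-out lower numbers stand for a weaker effect and higher numbers for a stronger effect at the one dose given), compound 1 gives 76.5%, and in this assay compound 2 gives 67.1%, so compound 2 stands within the usual scatter of its only neighbour on the numbers shown. For the measured compounds named here, the single measured step, a number 9.4 percentage points lower from compound 1 to compound 2 (within the scatter), is the only one that bears on the change to compound 3, `Cc1ccc(-c2noc(CN3C(=O)c4ccccc4C3=O)n2)cc1`. That change, (4-methylphenyl in place of 3-methylphenyl on an aromatic carbon), moves the methyl group around the same phenyl ring once more, so the measured step is its nearest guide, and it did not reach beyond the scatter. Compound 3 is therefore expected to stay close to compound 2, with a step of about a number 0.9 percentage points higher from compound 2 to compound 3 (within the scatter), no more than the scatter in either direction. The estimate for compound 3 is 68%, within a range from 50% to 82%.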

Compound 3, a percentage reported as inhibition, in the whole organism at one dose (the size of the read-out at that dose, not a potency): 16.1%
For compound 3 the middle estimate is 51.9 percentage points above the measured one; measured number below the stated range.
By their numbers in this assay, from the lowest: compound 3; then compounds 2 and 1 (each within the scatter of the next).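

At this position, on the aromatic carbon between two ring nitrogen atoms, the placement of the methyl group on the phenyl ring can matter greatly: replacing 3-methylphenyl with 4-methylphenyl gives a number 51 percentage points lower from compound 2 to compound 3 (beyond the scatter). Replacing 2-methylphenyl with 4-methylphenyl gives a number 60.4 percentage points lower from compound 1 to compound 3 (beyond the scatter), so in this assay the 4-methylphenyl group stands apart from the other two, which remain within the scatter of each other. Nothing available explains this loss of effect.

The compounds shown leave open whether the loss is specific to 4-methylphenyl or would also appear with another group at that ring position, such as 4-chlorophenyl or 4-methoxyphenyl. They also leave open where unsubstituted phenyl would fall, and, with readings at only one dose, how the full dose response of these compounds would compare.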